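One Fewer Methoxy Group in a Cytotoxicity Series

A few compounds are considered here, and "the series" means these few. Any claim that something is new, unique, unknown or untested is made for them only; others in the source may bear on it.

Measured compounds:
compound 1, `COc1ccc(-c2cc(/C=C/C(=O)c3ccc(N)cc3)[nH]n2)cc1`: 9%
compound 2, `COc1ccc(-c2cc(/C=C/C(=O)c3ccc(N)cc3)[nH]n2)cc1OC`: 37%
compound 3, `COc1cc(C(=O)/C=C/c2cc(-c3cc(OC)c(OC)c(OC)c3)n[nH]2)cc(OC)c1OC`: 12%

In a functional assay on NCI/ADR-RES cells (Homo sapiens) for cytotoxicity, read by sulforhodamine B assay, with a stated time of 48 h, tested at 10 uM (a higher number here means a weaker effect of the compound at the concentration tested, a lower number a stronger effect), compound 1 gives 9%, compound 2 gives 37% and compound 3 gives 12%. From compound 2 to compound 1 the change is hydrogen in place of methoxy on an aromatic carbon and the number moves a number 28 percentage points lower from compound 2 to compound 1 (beyond the scatter). How the core of compound 3 differs from that of compound 2 is not broken down here; compound 3 and compound 1 lie within the scatter of each other.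

Compound 4, `COc1ccc(-c2cc(/C=C/C(=O)c3cc(OC)c(OC)c(OC)c3)[nH]n2)cc1OC`, arises from compound 3 by the same kind of change: hydrogen in place of methoxy on an aromatic carbon. The surroundings are not identical, since here the place is also meta to a methoxy group. Compound 3 already stands low, so a drop as large as a number 28 percentage points lower from compound 2 to compound 1 (beyond the scatter) cannot recur. A step of a number 4 percentage points lower from compound 3 to compound 4 (within the scatter) is expected, because compound 3 gives 12% and that leaves little room. Compound 4 is therefore estimated at 8%, between 2% and 22%.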

Compound 4, a percentage reported as activity, at one concentration (the size of the read-out at that concentration, not a potency): 9%
The estimate for compound 4 lay 1 percentage points below the measured number, within the range that was stated.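

In this assay the exchange of methoxy for hydrogen gave a number 3 percentage points lower from compound 3 to compound 4 (within the scatter). Set beside the earlier step, the same change did not carry over in size from one core to the other: the same change on two cores in this assay, a number 28 percentage points lower (beyond the scatter) from compound 2 to compound 1 and a number 3 percentage points lower (within the scatter) from compound 3 to compound 4, 25 percentage points apart, beyond the scatter of two such steps. Among these compounds, with only two pairs, this does not show why the steps differ, nor how the change would behave on a third core.

The compounds shown leave open whether a hydroxyl or an ethoxy group in place of the methoxy group would shift the read-out on either core. They also leave open whether a carboxylic acid at that place would do so.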